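This account rests on a few compounds, and the source may have more. Where it says the series, first, only, none or still open, it means among the compounds named here.

Compound 1 `CCOC(=O)C(C)Nc1cccc2c(S(=O)(=O)Nc3onc(C)c3C)cccc12`: 400 nM
Compound 2 `Cc1noc(N(CC(=O)O)S(=O)(=O)c2ccc(N)cc2)c1C`: > 32000 nM

Among the compounds with values here, in an assay on VSM-A10 cells for antagonist activity at Endothelin-1 receptor (Rattus norvegicus) (a higher number here means a weaker inhibitor, a lower number a stronger inhibitor), compound 1 gives 400 nM, the only full number among the two values. Compound 2 reached only a limit of this assay, > 32000 nM, as noted in the limit of > 32000 nM in this assay, at which 1 of the 2 values shown sits. Compound 3 `Cc1noc(NS(=O)(=O)c2cccc3c(N4CCCC4=O)cccc23)c1C` is not yet measured. It differs from compound 1 in one place (2-oxopyrrolidin-1-yl in place of (1-(ethoxycarbonyl)ethyl)amino on an aromatic carbon). Within the data shown here, no measured step of this kind is known, so the expectation rests on compound 1 alone. A modest loss beyond the scatter is expected a 2.3-fold higher number from compound 1 to compound 3 (0.35 log units; beyond the scatter). For compound 3 the estimated value is 900 nM, ranging from 250 nM to 4000 nM.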

Compound 3, half-maximal inhibitory concentration: 130 nM
Estimate against measurement, compound 3: 6.9-fold (0.84 log units) above; the measured number lies below the stated range.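

In this assay, 2-oxopyrrolidin-1-yl in place of (1-(ethoxycarbonyl)ethyl)amino on this aromatic carbon gives a 3.1-fold lower number from compound 1 to compound 3 (0.49 log units; beyond the scatter). This position therefore keeps activity when the open chain, with its hydrogen-bond donor, gives way to a five-membered ring without one, so that donor is not required here. Nothing measured here bears on why the number falls. Still open, going by these compounds, is whether the ring itself matters, or only the carbonyl: an open-chain acetamide or a six-membered lactam at this position would separate the two.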